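Hydroxy in place of (1-phenylethyl)amino: cytotoxicity notes

The source may hold more compounds than are shown below. What is called first, only, known or untested is meant among the compounds shown, and "the series" means these compounds.

Compound 1 `CCCNCc1cc2c(cc(C(=O)N3CCC(C(=O)NCCC)CC3)n2Cc2ccc(OC)cc2)s1` gives > 100000 nM in an ADME assay on HEK-293T cells (Homo sapiens) for cytotoxicity, read by luminescence, with a stated time of 24 h (on this read-out lower numbers stand for higher toxicity in this test and higher numbers for lower toxicity in this test), and this is a limit of the assay, not a number. For the measured compounds named here, compound 2 `CCCNC(=O)C1CCN(C(=O)c2cc3sc(CNC(C)c4ccccc4)cc3n2Cc2ccc(OC)cc2)CC1` gives 33900 nM in this assay, the only true number so far. Compound 3 `CCCNC(=O)C1CCN(C(=O)c2cc3sc(CO)cc3n2Cc2ccc(OC)cc2)CC1` is still unmeasured and differs from compound 2 by hydroxy in place of (1-phenylethyl)amino on a saturated chain carbon bound to an aromatic carbon.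

Going by the values given here, one measured step bears on this change: an at least 2.9-fold lower number from compound 1 to compound 2 (0.46 log units; beyond the scatter), with 1-phenylethyl in place of propyl on an amine nitrogen. It shows a lower number when the 1-phenylethyl group is present, and compound 3 has lost that group. Among the compounds with values here, no measured step covers hydroxy replacing an amine, so the expectation is loose. A higher number than for compound 2 is expected in this assay, capped by the limit of > 100000 nM in this assay, at which 1 of the 2 values shown sits. The expected change is a 2.4-fold higher number from compound 2 to compound 3 (0.37 log units; beyond the scatter), a modest step toward lower toxicity in this test. For compound 3 the estimated value is 80000 nM, with an expected range of 35000 nM to 100000 nM.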

Compound 3, half-maximal cytotoxic concentration: 15500 nM
For compound 3 the middle estimate is 5.2-fold (0.71 log units) above the measured one; the measured number lies below the stated range.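

In this assay, the number at this position does not simply follow the 1-phenylethyl group: replacing (1-phenylethyl)amino with hydroxy gives a 2.2-fold lower number from compound 2 to compound 3 (0.34 log units; beyond the scatter), so removing the aromatic ring of that group does not by itself raise the number. Replacing propylamino with hydroxy points the same way, with an at least 6.4-fold lower number from compound 1 to compound 3 (0.80 log units; beyond the scatter), which places the hydroxymethyl compound lower than both compounds that carry an amine on this saturated chain carbon. The earlier link between a larger group on the amine nitrogen and a lower number therefore holds only from compound 1 to compound 2, and compound 3, which has no such amine and the lowest number of the three, goes against any simple reading of size at this position.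

From the compounds shown here alone, the true size of both steps that start from compound 1 stays unknown: the limit of > 100000 nM in this assay, at which 1 of the 3 values shown sits. Going by these compounds, whether the lower number belongs to the hydroxy group itself or to the loss of the amine nitrogen stays open, and a methyl ether, a carboxylic acid or an unsubstituted amine on this saturated chain carbon would help to separate the two.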